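Removing One Chloro from an Inactive Pair

The compounds below may be only part of what the source reports. "The series", "measured", "known", "first", "only" and "open" are said of these compounds alone.

In an ADME assay on HEK293 cells (Homo sapiens) for antiproliferative activity, read by MTT assay, with a stated time of 48 h (on this read-out lower numbers stand for stronger inhibition and higher numbers for weaker inhibition), compound 1 (`O=C(/C=C/c1cn(S(=O)(=O)c2ccc([N+](=O)[O-])cc2)c2ccccc12)c1ccncc1`) gives > 150000 nM, which is a limit of the assay and not a number. Compound 2 (`O=C(/C=C/c1cn(S(=O)(=O)c2ccc(Cl)cc2Cl)c2ccccc12)c1ccncc1`) gives > 150000 nM, and this too is a limit. Compound 2 therefore stands at the limit of > 150000 nM in this assay, at which 2 of the 2 values shown sit.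

Compound 3 (`O=C(/C=C/c1cn(S(=O)(=O)c2ccc(Cl)cc2)c2ccccc12)c1ccncc1`) is made from compound 2 by a single change: hydrogen in place of chloro on an aromatic carbon. Hydrogen takes the place of chloro on an aromatic carbon, so 2,4-dichlorophenyl becomes 4-chlorophenyl.

Within the data shown here, only one measured step bears on this change, and it is a step that the two limits leave unreadable from compound 1 to compound 2. Its size cannot be read, so it offers no direction and no true size to carry over. The expectation in this assay is therefore modest: no step beyond the usual scatter, with compound 3 most likely reported as a limit as well. The expected change, a step that the limit leaves unreadable from compound 2 to compound 3, is only an estimate resting on these two limits. For compound 3, the estimated value is 180000 nM, with an expected range from 80000 nM to 400000 nM.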

Compound 3, half-maximal inhibitory concentration: > 150000 nM
Compound 3: no number, only a limit (the forecaster's own chance of this, stated with the estimate: 80%); the middle value does not contradict the limit.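

In this assay compound 3 gives > 150000 nM, which is a limit of the assay and not a number. No step between compound 1, compound 2 and compound 3 can be read, and all three share one ceiling: the limit of > 150000 nM in this assay, at which 3 of the 3 values shown sit.

The compounds shown leave open whether 4-nitrophenyl, 2,4-dichlorophenyl and 4-chlorophenyl differ at all in this assay.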